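The source may report more compounds than this note shows. Statements on the series, on what has been measured and on what is new or still open speak of the compounds shown alone.

Measured compounds in a functional assay on CNE cells (Homo sapiens) for cytotoxicity, read by MTT assay, with a stated time of 72 h; on this read-out higher numbers stand for weaker inhibition and lower numbers for stronger inhibition:

compound 1, `CCOc1ccc(COc2c(OC)cc(/C=C/C(=O)OCC(=O)Nc3ccccc3)cc2OC)cc1`, gives > 200000 nM, which is a limit of the assay and not a number.
compound 2, `O=C(COC(=O)/C=C/c1ccc(O)c(O)c1)Nc1ccc(Cl)cc1`, gives 89600 nM.
compound 3, `COc1ccc(/C=C/C(=O)OCC(=O)Nc2ccccc2)cc1OC`, gives > 200000 nM, again a limit of the assay rather than a number.

Compound 1 therefore stands at the edge of what this assay can report. The same holds for compound 3; of the three values shown, only compound 2 yields a measured number. This is summed up in the observation (the limit of > 200000 nM in this assay, at which 2 of the 3 values shown sit).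

The next compound, compound 4, `CCOc1ccc(COc2c(OC)cc(/C=C/C(=O)OCC(=O)Nc3ccc(Cl)cc3)cc2OC)cc1`, differs from compound 1 by a single change: chloro in place of hydrogen on an aromatic carbon. Compound 2 also carries a chloro on its anilide ring and gives a number, but compound 2 differs from compound 1 in several other places, so no conclusion can be drawn from that pair alone.

Among the compounds with values here, with no measured step of this kind available, the expected step from compound 1 to compound 4 is none beyond the usual scatter, a step that the limit leaves unreadable from compound 1 to compound 4. Compound 4 is thus estimated at 250000 nM, in a range from 80000 nM to 800000 nM, and it is expected that this assay may again report only a limit.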

Compound 4, half-maximal inhibitory concentration: > 200000 nM
Compound 4 was reported as a limit; the forecaster's own chance of this, stated with the estimate: 70%; the middle value lies beyond the limit too.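

In this assay compound 4 gives > 200000 nM, which is a limit and not a number. Within the data shown here, compound 1 also sits at a limit, so no step between compound 1 and compound 4 can be read. The compounds shown leave open whether chloro in place of hydrogen on an aromatic carbon changes the activity of this series at all.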